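Swapping the naphthalene arm for a chlorobenzyl in a sulfonylguanidine series

This account rests on a few compounds, and the source may have more. Where it says the series, first, only, none or still open, it means among the compounds named here.

Measured so far:
compound 1, `Cc1cc(-c2ccccc2)n(/C(N)=N/S(=O)(=O)c2cc(C)c(Cl)cc2SCc2cccc3ccccc23)n1`, 3000 nM;
compound 2, `Cc1cc(-c2ccccc2)n(/C(N)=N/S(=O)(=O)c2cc(C)c(Cl)cc2SCc2cccc(Cl)c2)n1`, 8000 nM;
compound 3, `Cc1cc(S(=O)(=O)/N=C(\N)n2nccc2-c2ccccc2)c(SCc2cccc3ccccc23)cc1Cl`, 3000 nM.

In a functional assay on HeLa cells (Homo sapiens) for cytotoxicity, read by MTT assay, with a stated time of 72 h (a higher number here means a weaker inhibitor, a lower number a stronger inhibitor), compound 3 gives 3000 nM, and it sits level with compound 1, the two together at the low end of the three numbers, with no change at the digits printed from compound 1 to compound 3 (within the scatter). Compound 4, `Cc1cc(S(=O)(=O)/N=C(\N)n2nccc2-c2ccccc2)c(SCc2ccccc2Cl)cc1Cl`, differs from compound 3 by 2-chlorophenyl in place of naphthalen-1-yl on a saturated chain carbon bound to a sulfur. Within the data shown here, the one measured step that bears on this is the loss of the same naphthalene group for a chlorophenyl: a 2.7-fold higher number from compound 1 to compound 2 (0.43 log units; beyond the scatter). A step of about that size, toward a higher number in this assay, is therefore expected for a 2.3-fold higher number from compound 3 to compound 4 (0.37 log units; beyond the scatter). Compound 4 is thus estimated at 7000 nM, within the range 3000 nM to 16000 nM.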

Compound 4, half-maximal inhibitory concentration: 19000 nM
Compound 4: the middle estimate sits 2.7-fold (0.43 log units) below what was measured; measured number above the stated range.
By their numbers in this assay, from the lowest: compounds 1 and 3 (each within the scatter of the next); then compound 2; then compound 4.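

In this assay, replacing naphthalen-1-yl with 2-chlorophenyl on the saturated chain carbon bound to a sulfur gives a 6.3-fold higher number from compound 3 to compound 4 (0.80 log units; beyond the scatter), in the same direction as a 2.7-fold higher number from compound 1 to compound 2 (0.43 log units; beyond the scatter). Both chlorophenyl replacements at this place therefore raise the number, and neither pair goes against this. The two steps differ in the chlorophenyl group and in the core, so their sizes cannot be set against each other, and no measurement here explains either step. Still open, on these data alone, is how an unsubstituted phenyl or a 4-chlorophenyl would behave here.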